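Benzyl to methyl exchange in an aorta series

This account rests on a few compounds, and the source may have more. Where it says the series, first, only, none or still open, it means among the compounds named here.

The read-out throughout is a functional assay on aorta (Rattus norvegicus); on this read-out lower numbers stand for stronger inhibition and higher numbers for weaker inhibition.
Compound 1 `O=c1ccc(CCOCc2ccccc2)nn1Cc1ccccc1`: 32300 nM
Compound 3 `O=c1ccc(CCCOCc2ccccc2)nn1Cc1ccccc1`: 32500 nM
Compound 2 `Cn1nc(CCOCc2ccccc2)ccc1=O`: > 100000 nM, which is a limit of the assay and not a number.

Compound 1 and compound 3 lie within the scatter of each other; the difference between their two cores is not broken down here. Compound 2 arises from compound 1 by hydrogen in place of phenyl on a saturated chain carbon bound to an aromatic nitrogen, and this gave an at least 3.0-fold higher number from compound 1 to compound 2 (0.49 log units; beyond the scatter), with compound 2 sitting at the limit of > 100000 nM in this assay, at which 1 of the 3 values shown sits. Compound 4 `Cn1nc(CCCOCc2ccccc2)ccc1=O` arises from compound 3 by the same change, (hydrogen in place of phenyl on a saturated chain carbon bound to an aromatic nitrogen). In this assay compound 4 is therefore expected to give 120000 nM. The expected step of a 3.7-fold higher number from compound 3 to compound 4 (0.57 log units; beyond the scatter) is set to resemble the earlier one, resting on an at least 3.0-fold higher number from compound 1 to compound 2 (0.49 log units; beyond the scatter) and on (the limit of > 100000 nM in this assay, at which 1 of the 3 values shown sits), so a second limit rather than a number is the likely outcome for compound 4.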

Compound 4, half-maximal inhibitory concentration: 76400 nM
Beside the measured number, compound 4's estimate is 1.6-fold (0.20 log units) above it; low and high end bracket the measured number.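

In this assay, benzyl to methyl on the core of compound 3 gives a 2.4-fold higher number from compound 3 to compound 4 (0.37 log units; beyond the scatter) and leaves compound 4 with a weaker read-out than compound 3. The change moves the number the same way on both cores shown, but a constant size for the step is not established: the same change on two cores in this assay, an at least 3.0-fold higher number (0.49 log units; beyond the scatter) from compound 1 to compound 2 and a 2.4-fold higher number (0.37 log units; beyond the scatter) from compound 3 to compound 4; the limit leaves it open whether they differ
For the compounds shown here, the value of compound 2, > 100000 nM, is a limit of the assay and not a number, so the carry-over rests on two cores and only one exact step.

Going by these compounds, whether the step holds on cores with a longer chain stays open. Also open, on these data alone, is how a carboxylic acid or an amine in place of the benzyl group would read in this assay on these cores.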